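From Ethynylphenyl to Bromofluorophenyl on Compound 3

The compounds below may be only part of what the source reports. "The series", "measured", "known", "first", "only" and "open" are said of these compounds alone.

In a functional assay on NCI-H1975 cells (Homo sapiens) for cytotoxicity, read by MTT assay, with a stated time of 72 h (on this read-out higher numbers stand for weaker inhibition and lower numbers for stronger inhibition), compound 1 (`CN1CCN(c2ccc(Nc3ncc4nc(Nc5ccccc5)n(-c5ccccc5)c4n3)cc2)CC1`) gives 1830 nM and compound 2 (`CC(=O)Nc1ccc(Nc2ncc3nc(Nc4ccccc4)n(C4CCCC4)c3n2)cc1`) gives 1210 nM. Compound 3 (`C#Cc1cccc(Nc2nc3cnc(Nc4ccc(N5CCN(C)CC5)cc4)nc3n2C2CCCC2)c1`) gives 650 nM, a number within the scatter of compound 2 and beyond the scatter below compound 1. Compound 4 (`CN1CCN(c2ccc(Nc3ncc4nc(Nc5ccc(Br)cc5F)n(C5CCCC5)c4n3)cc2)CC1`) differs from compound 3 in one place, with 4-bromo-2-fluorophenyl in place of 3-ethynylphenyl on a nitrogen on an aromatic ring. Within the data shown here, no measured pair of compounds shows this change, so the data offer no firm direction for it. The expected step is a 1.1-fold lower number from compound 3 to compound 4 (0.03 log units; within the scatter), which would stay within the scatter. Compound 4 is estimated at 600 nM, with an expected range of 180 nM to 2000 nM.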

Compound 4, half-maximal inhibitory concentration: 1120 nM
The estimate for compound 4 lay 1.9-fold (0.27 log units) below the measured number; the measured number falls inside the stated range.
By their numbers in this assay, from the lowest: compounds 3, 4, 2 and 1 (each within the scatter of the next, the first and the last beyond it).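

In this assay, among these compounds, the position on this nitrogen can now be read directly for the first time: 4-bromo-2-fluorophenyl in place of 3-ethynylphenyl gives a step that stays within the scatter (a 1.7-fold higher number from compound 3 to compound 4 (0.24 log units; within the scatter)). With the rest of compound 3 unchanged, this exchange of one aromatic ring for another therefore leaves the number essentially where it was. Nothing available explains this outcome. As far as these compounds go, the bromine and fluorine enter together, so their separate contributions remain open. Also open, from the compounds shown here alone, is whether an amine or a carboxylic acid on this ring would move the number beyond the scatter.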